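Pyrazole isomer swap in an oral exposure series

The compounds below may be only part of what the source reports. "The series", "measured", "known", "first", "only" and "open" are said of these compounds alone.

Measured compounds:
compound 1, `CCN1CCN(c2cc(Nc3cc(C)nn3C(=O)OC(C)(C)C)nc(N[C@H]3CCN(C(=O)c4ccc(Cl)cc4F)C3)n2)CC1`, 1100 nM
compound 2, `CCOC(=O)n1nc(C)cc1Nc1cc(N2CCN(CC)CC2)nc(N[C@H]2CCN(C(=O)c3ccc(Cl)cc3F)C2)n1`, 1820 nM

Of the compounds shown here, two have been measured in an ADME assay on the whole organism (Mus musculus, strain ICR) for pharmacokinetics, read by LC-MS, with a stated time of 24 h, at a dose of 10 mg/kg by the oral route; a lower number here means less compound in the circulation, a higher number more compound in the circulation at the dose given. Compound 2 gives 1820 nM and stands highest of the two numbers, with compound 1 nearest at a 1.7-fold higher number from compound 1 to compound 2 (0.22 log units; within the scatter), a step that stays within the scatter. That one step concerns the ester group only: ethyl in place of tert-butyl on an oxygen next to a carbonyl group.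

Compound 3, `CCOC(=O)n1nc(Nc2cc(N3CCN(CC)CC3)nc(N[C@H]3CCN(C(=O)c4ccc(Cl)cc4F)C3)n2)cc1C`, has not been measured. It carries the same atoms as compound 2, joined differently: 1-(ethoxycarbonyl)-5-methyl-1H-pyrazol-3-yl in place of 1-(ethoxycarbonyl)-3-methyl-1H-pyrazol-5-yl on a nitrogen on an aromatic ring. Among the compounds with values here, no measured step touches this kind of change; the single step from compound 1 to compound 2 alters the ester, not the pyrazole attachment, and is itself within the scatter. Compound 3 is therefore expected to give a number close to that of compound 2, with a step estimated at a 1.2-fold lower number from compound 2 to compound 3 (0.08 log units; within the scatter) and no direction favoured beyond the scatter. For compound 3 the expected value is 1500 nM, with a range from 500 nM to 4500 nM.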

Compound 3, maximal plasma concentration: 457 nM
Estimate against measurement, compound 3: 3.3-fold (0.52 log units) above; the whole stated range lies above it.
By their numbers in this assay, from the lowest: compound 3; then compounds 1 and 2 (each within the scatter of the next).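

In this assay, the way the pyrazole is joined to the nitrogen on the aromatic ring matters: 1-(ethoxycarbonyl)-5-methyl-1H-pyrazol-3-yl in place of 1-(ethoxycarbonyl)-3-methyl-1H-pyrazol-5-yl gives a 4.0-fold lower number from compound 2 to compound 3 (0.60 log units; beyond the scatter), with the same atoms throughout. The earlier step on the ester, a 1.7-fold higher number from compound 1 to compound 2 (0.22 log units; within the scatter), stayed within the scatter, so this change of attachment is the only one shown that moves the number beyond it. No measurement at hand speaks to what lies behind this difference.

The compounds shown leave open whether the same swap would lower the number when the pyrazole carries the tert-butyl ester of compound 1. They also leave open how the 3-yl and 5-yl attachments would compare with an acetyl or a methylsulfonyl group in place of ethoxycarbonyl.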